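The source may report more compounds than this note shows. Statements on the series, on what has been measured and on what is new or still open speak of the compounds shown alone.

Working notes on the series, in a functional assay for activation of Alpha-1D adrenergic receptor (Homo sapiens); on this read-out lower numbers stand for an effect already at smaller amounts and higher numbers for an effect only at larger amounts of compound.

Compound 1 `c1coc(-c2ccccc2NCC2=NCCN2)c1` carries furan-2-yl and gives 16.2 nM in this assay. Compound 2 `c1ccc(-c2cnoc2)c(NCC2=NCCN2)c1` carries 1,2-oxazol-4-yl in the same place. For compound 2 this assay yields only a limit, < 100000 nM, and no number. The step that the limit leaves unreadable from compound 1 to compound 2 therefore cannot be sized; what is known of it is summed up in the limit of < 100000 nM in this assay, at which 1 of the 2 values shown sits.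

Compound 3 `c1ccc(-c2ccccc2NCC2=NCCN2)nc1` is not yet measured. The change from compound 2 is pyridin-2-yl in place of 1,2-oxazol-4-yl on an aromatic carbon. No measured step sizes this exchange directly. Among the measured compounds shown here, the only comparison at hand, between compound 1 and compound 2, says that a change of the five-membered ring can move the read-out from a clean number to a limit, so the ring in this place matters.

Compound 3 is expected to return to a readable value, with an estimated 150 nM and a range from 10 nM to 5000 nM. The estimated step that the limit leaves unreadable from compound 2 to compound 3 is thus expected to be large and toward an effect at smaller amounts.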

Compound 3, half-maximal effective concentration: 41.7 nM
Beside the measured number, compound 3's estimate is 3.6-fold (0.56 log units) above it, within the range that was stated.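

Pyridin-2-yl in place of furan-2-yl gives a 2.6-fold higher number from compound 1 to compound 3 (0.41 log units; beyond the scatter) in this assay, so a readable value at this place is not confined to a five-membered aromatic ring. A six-membered aromatic ring with 1 hetero atom is accepted here with only a modest shift, and among the three compounds shown, 1,2-oxazol-4-yl alone goes against a readable value. No step to or from compound 2 can be read, because compound 2 gives only a limit: the limit of < 100000 nM in this assay, at which 1 of the 3 values shown sits.

Open, from the compounds shown here alone, is how a plain phenyl or a pyridin-3-yl would read at this place, which would separate the role of the ring size from that of the ring nitrogen. Also open, going by these compounds, is whether the pyridin-2-yl ring tolerates an added group such as an amine or a carboxylic acid.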